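From cyclopentyl to cyclopropyl: notes on compound 4

This account rests on a few compounds, and the source may have more. Where it says the series, first, only, none or still open, it means among the compounds named here.

In a functional assay on PC-12 cells (Rattus norvegicus) for inhibition, read by sulforhodamine B assay (on this read-out lower numbers stand for stronger inhibition and higher numbers for weaker inhibition), compound 1 (`O=C1NC(=O)C(Cc2ccc(OCC3CCCCC3)cc2)S1`) gives 26000 nM and compound 2 (`O=C1N=C(O)S/C1=C\c1ccc(OCC2CCCCC2)cc1`) gives 14000 nM, while compound 3 (`O=C1NC(=O)C(Cc2ccc(OCC3CCCC3)cc2)S1`) gives 25000 nM and so sits within the scatter of both. Compound 4 (`O=C1NC(=O)C(Cc2ccc(OCC3CC3)cc2)S1`) has cyclopropyl in place of cyclopentyl on a saturated chain carbon bound to an oxygen on an aromatic ring. For the measured compounds named here, the only measured step bearing on this, cyclopentyl in place of cyclohexyl at the same place, is a 1.0-fold lower number from compound 1 to compound 3 (0.02 log units; within the scatter) and stays within the scatter. One step is thin support, but no change beyond the scatter is expected in this assay (estimated step: a 1.1-fold higher number from compound 3 to compound 4 (0.03 log units; within the scatter)). For compound 4 the estimated value is 27000 nM (13000 nM to 55000 nM).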

Compound 4, half-maximal inhibitory concentration: > 100000 nM
Compound 4 ended at the assay's limit; the forecaster's own chance of this, stated with the estimate: 15%; middle value at least 3.7-fold (0.56 log units) from the limit.
By their numbers in this assay, from the lowest: compounds 2, 3 and 1 (each within the scatter of the next). At a limit, above all of these: compound 4.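

In this assay, this position does not accept every ring size: cyclohexyl and cyclopentyl stay within the scatter of each other (a 1.0-fold lower number from compound 1 to compound 3 (0.02 log units; within the scatter)), but cyclopropyl does not. The change to cyclopropyl gives an at least 4.0-fold higher number from compound 3 to compound 4 (0.60 log units; beyond the scatter), and an at least 3.8-fold higher number from compound 1 to compound 4 (0.58 log units; beyond the scatter). Compound 4 stands at a limit of the assay, so the full size of both steps stays unknown: the limit of > 100000 nM in this assay, at which 1 of the 4 values shown sits.

Open, as far as these compounds go, is where between cyclopentyl and cyclopropyl the weakening sets in, which cyclobutyl at the same place would show. Also open, from the compounds shown here alone, is how an amine or a longer chain there would read.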